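The compounds below may be only part of what the source reports. "The series", "measured", "known", "first", "only" and "open" are said of these compounds alone.

In an ADME assay on HEK-293T cells (Homo sapiens) for cytotoxicity, read by MTT assay, with a stated time of 24 h (on this read-out higher numbers stand for lower toxicity in this test and lower numbers for higher toxicity in this test), the measured compounds stand as follows.
Compound 1 `O=S(=O)(c1ccc(F)cc1)n1c(-c2cn(-c3ccccc3)nc2-c2ccc(F)cc2)nc2ccccc21` gives 218000 nM
Compound 2 `O=S(=O)(c1ccc(Br)cc1)n1c(-c2cn(-c3ccccc3)nc2-c2ccc(F)cc2)nc2ccccc21` gives 239000 nM
Compound 3 `O=S(=O)(c1ccc(C(F)(F)F)cc1)n1c(-c2cn(-c3ccccc3)nc2-c2ccc(F)cc2)nc2ccccc21` gives 241000 nM

Compound 1 sits level with the other two, with no order among the three: a 1.1-fold higher number from compound 1 to compound 2 (0.04 log units; within the scatter) and a 1.1-fold higher number from compound 1 to compound 3 (0.04 log units; within the scatter) both lie within the scatter, as does a 1.0-fold higher number from compound 2 to compound 3 (0.00 log units; within the scatter). Still unmeasured is compound 4 `O=S(=O)(c1ccc(F)cc1)n1c(-c2cn(-c3ccccc3)nc2-c2ccc(C(F)(F)F)cc2)nc2ccccc21`, which differs from compound 1 by trifluoromethyl in place of fluoro on an aromatic carbon. In words, this is trifluoromethyl in place of fluoro on an aromatic carbon, para to a large group, with 4-fluorophenyl becoming 4-(trifluoromethyl)phenyl. The same exchange of groups appears in a 1.1-fold higher number from compound 1 to compound 3 (0.04 log units; within the scatter) at another site of the molecule, which makes that step the closest guide but not a direct one. For the measured compounds named here, all three measured compounds keep the 4-fluorophenyl group, so no measurement yet tests a change at that site. The data therefore give no reason to expect a shift in either direction, and the estimated step is a 1.0-fold higher number from compound 1 to compound 4 (0.01 log units; within the scatter) and is expected to stay within the scatter. For compound 4 the estimated value is 225000 nM with an expected range from 110000 nM to 400000 nM in this read-out.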

Compound 4, half-maximal cytotoxic concentration: 157000 nM
The estimate for compound 4 lay 1.4-fold (0.16 log units) above the measured number; low and high end bracket the measured number.
By their numbers in this assay, from the lowest: compounds 4, 1, 2 and 3 (each within the scatter of the next).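

In this assay, the exchange at the 4-fluorophenyl group gives a 1.4-fold lower number from compound 1 to compound 4 (0.14 log units; within the scatter). For the compounds shown here, this is the first reading at this site: 4-(trifluoromethyl)phenyl in place of 4-fluorophenyl, para to a large group, stays within the scatter, so this single exchange shows no measurable effect on the read-out. The same exchange of groups at the other site gives a 1.1-fold higher number from compound 1 to compound 3 (0.04 log units; within the scatter), also within the scatter, so across the two sites trifluoromethyl in place of fluoro has not separated from compound 1, and no evidence at hand bears on the result.

Still open, on these data alone, is whether a group of another kind at the 4-fluorophenyl site, such as an amine, a carboxylic acid or a longer alkyl chain, would take the number beyond the scatter. Also open is how a molecule carrying trifluoromethyl at both sites would read in this assay, as the compounds shown have this group at only one site at a time.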